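Swapping the group on the sulfonyl sulfur of compound 2

The source may report more compounds than this note shows. Statements on the series, on what has been measured and on what is new or still open speak of the compounds shown alone.

Compound 1 `Cc1cc(C)c(S(=O)(=O)N2CCN(C3CN4CCC3CC4)CC2)c(C)c1`: > 5000 nM, a limit
Compound 2 `Cc1noc(C)c1S(=O)(=O)N1CCC(N2CCC(C)CC2)CC1`: > 10000 nM, a limit
Compound 3 `CC1CCN(C2CCN(S(=O)(=O)c3cccc4ccccc34)CC2)CC1`: > 10000 nM, a limit

All three results from an ADME assay on HCT-116 cells (Homo sapiens) for cytotoxicity, read by CellTiter-Glo, with a stated time of 72 h (on this read-out lower numbers stand for stronger inhibition and higher numbers for weaker inhibition), are limits, not exact numbers. Compound 2 stands at the limit of > 10000 nM in this assay, at which 2 of the 3 values shown sit, and compound 3 shares that limit. Compound 4 `CC1CCN(C2CCN(S(=O)(=O)c3cccc(N)c3)CC2)CC1` has 3-aminophenyl in place of 3,5-dimethyl-1,2-oxazol-4-yl on a sulfonyl sulfur. With the core of compound 2 and another group on the sulfonyl sulfur, compound 3 also gives > 10000 nM, a limit. In this assay, no change beyond the scatter is therefore expected for the step of a number no higher from compound 2 to compound 4 (the limit leaves the size open). For compound 4 the estimated value is 10000 nM, with an expected range of 3000 nM to 30000 nM.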

Compound 4, half-maximal inhibitory concentration: > 5000 nM
Compound 4 was reported as a limit (the forecaster's own chance of this, stated with the estimate: 80%); the middle value is on the limit's open side.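

No step can be read from compound 2 to compound 4: both results are limits, not exact numbers. The compounds shown leave open whether 3-aminophenyl in place of 3,5-dimethyl-1,2-oxazol-4-yl changes the result in this assay at all.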